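Three Pyrazole Analogues Without Effect, and a Fourth to Test

This account rests on a few compounds, and the source may have more. Where it says the series, first, only, none or still open, it means among the compounds named here.

A short series of pyrazole-bearing compounds was examined in a functional assay on MDA-MB-435 cells (Homo sapiens) for cytotoxicity, read by sulforhodamine B assay, with a stated time of 48 h, tested at 0.001 uM; on this read-out higher numbers stand for a weaker effect at the one concentration tested and lower numbers for a stronger effect. Compound 1 `COc1cc(C)cc(-c2c(-c3ccnc(-c4ccc(C(C)=O)cc4)c3)cnn2CC#N)c1` gives 100%, and compound 2 `COc1cc(C)cc(-c2nn(CC#N)cc2-c2ccc(-c3cccc(C(C)=O)c3)nc2)c1` gives 101%. Compound 3 `Cc1cc(O)cc(-c2nn(CC#N)cc2-c2ccnc(-c3ccc(Oc4ccccc4)cc3)c2)c1` gives 103%, a number that sits alongside those of compound 2 and compound 1, since both gaps lie within the scatter; the three compounds therefore stand together, none set apart from the others, and none of the three shows any appreciable effect at the concentration tested.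

Compound 4 `Cc1cc(O)cc(-c2nn(CC#N)cc2-c2ccnc(-c3ccc(N(C)C)cc3)c2)c1` has not yet been measured. It differs from compound 3 by dimethylamino in place of phenoxy on an aromatic carbon. For the measured compounds named here, no step between two measured compounds that differ in a single place is available here, so the expectation for this change rests on the three values alone, all of which sit close to one another.

The step from compound 3 to compound 4 is expected to be a number 3 percentage points lower from compound 3 to compound 4 (within the scatter), that is, no change beyond the scatter in this assay. Compound 4 is estimated to give 100% in this assay, within a range from 90% to 110%.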

Compound 4, a percentage reported as activity, at one concentration (the size of the read-out at that concentration, not a potency): 99%
Compound 4: the middle estimate sits 1 percentage points above what was measured; the range from low to high includes it.
By their numbers in this assay, from the lowest: compounds 4, 1, 2 and 3 (each within the scatter of the next).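

For the compounds shown here, compound 4 gives the first comparison that differs in one place, with dimethylamino in place of phenoxy on an aromatic carbon, para to a large group. In this assay the step is a number 4 percentage points lower from compound 3 to compound 4 (within the scatter), so removing the six-membered aromatic ring of carbon only and going from 7 heavy atoms to 3 at this position leaves no difference beyond the scatter at this one concentration. No measured information on any property of these compounds bears on this result.

Since none of the compounds shows an appreciable effect at this concentration, the compounds shown leave open whether this position matters at higher concentrations. They also leave open how a carboxylic acid or a morpholine group on the same carbon would read out.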